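The source may hold more compounds than are shown below. What is called first, only, known or untested is meant among the compounds shown, and "the series" means these compounds.

Measured so far in a functional assay on MDA-MB-231 cells (Homo sapiens) for cytotoxicity, read by MTT assay, with a stated time of 48 h; on this read-out lower numbers stand for stronger inhibition and higher numbers for weaker inhibition:
Compound 1 `COc1ccccc1Nc1nc(-c2cccc(F)c2)nc2ccc(F)cc12` gives > 50000 nM, which is a limit of the assay and not a number.
Compound 2 `Fc1cccc(-c2nc(Nc3ccccc3F)c3cc(F)ccc3n2)c1` gives > 50000 nM, again a limit of the assay.
Compound 3 `Fc1cccc(-c2nc(Nc3ccccc3Cl)c3cc(F)ccc3n2)c1` gives > 50000 nM, again a limit of the assay.

Compound 2 therefore stands at the limit, as do the two other values shown (the limit of > 50000 nM in this assay, at which 3 of the 3 values shown sit). The steps a step that the two limits leave unreadable from compound 1 to compound 2, a step that the two limits leave unreadable from compound 1 to compound 3 and a step that the two limits leave unreadable from compound 2 to compound 3 cannot be sized because the limit of > 50000 nM in this assay, at which 3 of the 3 values shown sit, holds both ends of each.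

Compound 4 `Oc1cccc(Nc2nc(-c3cccc(F)c3)nc3ccc(F)cc23)c1` differs from compound 2 by 3-hydroxyphenyl in place of 2-fluorophenyl on a nitrogen on an aromatic ring. Among the measured compounds shown here, none of the measured steps exchanges the whole aryl group on that nitrogen; each exchanges a single substituent on that ring, and none has a readable size. For the measured compounds named here, no step of readable size therefore bears on this change, and the expectation for compound 4 in this assay rests on the three limits alone. The step of a number no higher from compound 2 to compound 4 (the limit leaves the size open) from compound 2 to compound 4 is expected to be none beyond the scatter, most likely another limit. Compound 4 is estimated at 50000 nM, with a range of 15000 nM to 150000 nM.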

Compound 4, half-maximal inhibitory concentration: > 50000 nM
Compound 4 gave a limit, no number; the forecaster's own chance of this, stated with the estimate: 75%; the middle value sits exactly at the limit.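

The steps from compound 1, compound 2 and compound 3 to compound 4 cannot be read, because both ends of each are held by a limit: the limit of > 50000 nM in this assay, at which 4 of the 4 values shown sit.

The compounds shown leave open what size any exchange of the aryl group on that nitrogen has in this assay, as none of them gives a number.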